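A few compounds are considered here, and "the series" means these few. Any claim that something is new, unique, unknown or untested is made for them only; others in the source may bear on it.

Measured so far:
compound 1 `CC1=C(C(=O)OCc2ccccn2)C(c2ccco2)C2=C(CCCC2=O)N1` — 1.4
compound 2 `CCCC1C(C(=O)OCc2cccnc2)=C(C)NC2=C1C(=O)CCC2` — 2.23
compound 3 `CC1=C(C(=O)OCc2cccnc2)C(c2cccs2)C2=C(CCCC2=O)N1` — 1.4

In a physicochemical assay for lipophilicity, measured as octanol-water partition (a higher number here means a more lipophilic compound, a lower number a more polar compound), compound 1 gives 1.4. It stands level with compound 3 at the digits printed, the two together the lowest of the three numbers; its nearest neighbour is compound 3, with no change at the digits printed, and its furthest is compound 2, whose value lies higher than that of compound 1 by a gap beyond the scatter.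

The unmeasured compound 4 `CC1=C(C(=O)OCc2ccccn2)C(c2cccc([N+](=O)[O-])c2)C2=C(CCCC2=O)N1` differs from compound 1 in one place: 3-nitrophenyl in place of furan-2-yl on a saturated ring carbon

Within the data shown here, the only measured step at this position is a number 0.83 log units lower from compound 2 to compound 3 (beyond the scatter). That step swaps a chain for a five-membered aromatic ring and does not cover the present exchange, so no direct measure of furan-2-yl against 3-nitrophenyl exists in the series. Compound 1 and compound 3 show that furan-2-yl and thiophen-2-yl give the same number at this place, which is all that can be read from them. With a larger group entering, a modest rise in this assay is expected for compound 4, estimated as a number 0.40 log units higher from compound 1 to compound 4 (beyond the scatter). Compound 4 is thus estimated at 1.8, within a range from 1.3 to 2.4.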

Compound 4, partition coefficient: 1.88
The estimate for compound 4 lay 0.08 log units below the measured number; the range from low to high includes it.
By their numbers in this assay, from the lowest: compounds 1 and 3 (each within the scatter of the next); then compound 4; then compound 2.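

In this assay, among these compounds, the step of a number 0.48 log units higher from compound 1 to compound 4 (beyond the scatter) is the only measured exchange between two aromatic groups on this saturated ring carbon, and it shows that the number at this place responds to which aromatic group sits there, not only to a chain giving way to a ring. Its direction is opposite to that of a number 0.83 log units lower from compound 2 to compound 3 (beyond the scatter) for the exchange of propyl for thiophen-2-yl on the same carbon, so within these compounds an aromatic group at this place does not fix the direction of the number. Nothing measured on these groups bears on the origin of the step.

From the compounds shown here alone, the exchange changes the aromatic ring and brings in the nitro group together, so the share of each in the step remains open, and plain phenyl at this carbon would separate the two. Also open, going by these compounds, is how the number behaves with an amine or a carboxylic acid on that phenyl ring, or with a longer chain in place of propyl on the shared core.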